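Aryl Variation on the Shared Core: Outlook for Compound 4

The source may hold more compounds than are shown below. What is called first, only, known or untested is meant among the compounds shown, and "the series" means these compounds.

The series keeps the core of compound 1 `O=C1/C(=C/c2ccccc2Br)NS(=O)(=O)c2ccccc21` and changes only the aryl group on the double-bonded chain carbon. In an assay for inhibition of alkaline phosphatase, tissue-nonspecific isozyme (Homo sapiens), read by spectrophotometry, with stated times of 10 min and 20 min (on this read-out higher numbers stand for weaker inhibition and lower numbers for stronger inhibition), compound 1 gives > 200000 nM, which is a limit of the assay rather than a number. Compound 2 `O=C1/C(=C/c2cccc(Br)c2)NS(=O)(=O)c2ccccc21` carries 3-bromophenyl in place of 2-bromophenyl. In this assay compound 2 gives > 200000 nM, again a limit. Compound 3 `O=C1/C(=C/c2ccc(Cl)cc2Cl)NS(=O)(=O)c2ccccc21` carries a dichlorophenyl group instead. In this assay compound 3 gives > 200000 nM, also a limit. The step that the two limits leave unreadable from compound 1 to compound 2 is therefore of no readable size, and the whole set of measured values sits at one limit (the limit of > 200000 nM in this assay, at which 3 of the 3 values shown sit).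

Compound 4 `O=C1/C(=C/c2ccc(F)cc2)NS(=O)(=O)c2ccccc21` differs from compound 1 by 4-fluorophenyl in place of 2-bromophenyl on a double-bonded chain carbon bound to a double-bonded ring carbon. Among the compounds with values here, the only measured step that bears on a change of this aryl group, from compound 1 to compound 2, is unreadable, and compound 3 adds no readable size either. Within the data shown here, no measured step gives a direction. Compound 4 is thus expected to remain at the limit in this assay, with an estimate of 200000 nM and a range from 100000 nM to 400000 nM. The step this estimate implies, a number no higher from compound 1 to compound 4 (the limit leaves the size open), is expected to be none beyond the scatter.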

Compound 4, half-maximal inhibitory concentration: 1350 nM
For compound 4 the middle estimate is 150-fold (2.17 log units) above the measured one; the measured number lies below the stated range.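

Notes on the aryl position: in this assay this position is not uniformly silent, as 4-fluorophenyl in place of 2-bromophenyl gives an at least 140-fold lower number from compound 1 to compound 4 (2.17 log units; beyond the scatter), and 4-fluorophenyl in place of 3-bromophenyl gives an at least 140-fold lower number from compound 2 to compound 4 (2.17 log units; beyond the scatter). Both changes swap one halogen-bearing phenyl group for another with the same number of heavy atoms and the same hydrogen-bond donor and acceptor counts, so these counts alone do not account for the change, and what differs is the halogen and where it sits on the ring. Compound 4 is the only compound in the set with a readable number, and the rest remain at one limit: the limit of > 200000 nM in this assay, at which 3 of the 4 values shown sit.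

The change from 2-bromophenyl or 3-bromophenyl to 4-fluorophenyl alters the halogen and its ring place together, so their contributions stay unresolved until 4-bromophenyl and 2-fluorophenyl are compared on the shared core. Also open, on these data alone, is whether a halogen is needed at all, a question that unsubstituted phenyl or a 4-methoxyphenyl or 4-carboxyphenyl group on the double-bonded chain carbon could address.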